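The source may hold more compounds than are shown below. What is called first, only, known or untested is meant among the compounds shown, and "the series" means these compounds.

In a functional assay on NCI-H838 cells (Homo sapiens) for antiproliferative activity, read by MTT assay, with a stated time of 72 h (a higher number here means a weaker inhibitor, a lower number a stronger inhibitor), compound 2 `C=CC(=O)Nc1cc2c(Nc3cccc(Cl)c3F)ncnc2cc1OCc1cn(CCCCC(=O)NO)nn1` gives > 50000 nM, a limit of the assay and not a number. Compound 1 `C=CC(=O)Nc1cc2c(Nc3ccc(F)c(Cl)c3)ncnc2cc1OCc1cn(CCC(=O)NO)nn1` gives > 50000 nM, also a limit. Compound 3 `C=CC(=O)Nc1cc2c(Nc3ccc(F)c(Cl)c3)ncnc2cc1OCc1cn(CCCCC(=O)NO)nn1` gives > 50000 nM, again a limit. Compound 4 `C=CC(=O)Nc1cc2c(Nc3cccc(Cl)c3F)ncnc2cc1OCc1cn(CCC(=O)NO)nn1` departs from compound 2 by hydroxycarbamoyl in place of 2-(hydroxycarbamoyl)ethyl on a saturated chain carbon, two bonds along the chain from an aromatic nitrogen. The same exchange, run in the opposite direction on a different aniline substituent, appears as a step that the two limits leave unreadable from compound 1 to compound 3. The other measured step, a step that the two limits leave unreadable from compound 2 to compound 3, is equally silent on size. The whole record is the limit of > 50000 nM in this assay, at which 3 of the 3 values shown sit. No direction can therefore be drawn from these steps, and the step expected is a step that the limit leaves unreadable from compound 2 to compound 4, with nothing beyond the scatter anticipated. Compound 4 is estimated at 60000 nM, within an expected range of 25000 nM to 120000 nM.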

Compound 4, half-maximal inhibitory concentration: > 50000 nM
Compound 4 ended at the assay's limit; the forecaster's own chance of this, stated with the estimate: 85%; the middle value does not contradict the limit.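

Neither step from compound 1 or compound 2 to compound 4 can be read, because every value is a limit and not a number: the limit of > 50000 nM in this assay, at which 4 of the 4 values shown sit.

The compounds shown leave open whether chain length, or the choice between 3-chloro-2-fluorophenyl and 3-chloro-4-fluorophenyl, changes antiproliferative activity at all.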